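From Thiophen-2-yl to Methoxy

A few compounds are considered here, and "the series" means these few. Any claim that something is new, unique, unknown or untested is made for them only; others in the source may bear on it.

In a functional assay on PC-3 cells (Homo sapiens), read by wound healing assay, with a stated time of 24 h (a higher number here means a weaker inhibitor, a lower number a stronger inhibitor), compound 2 `O=C1NC(=O)/C(=C/c2cccc(-c3cccs3)n2)N1` gives 30800000 nM. Going by the values given here, that is the only number available for it, and a further entry for compound 2 carries no single number. Among the compounds with values here, the only other measured compound is compound 1 `O=C1NC(=O)/C(=C/c2ccc(OCC(=O)N3CCOCC3)cc2)N1`, which gives 10600000 nM; 94000 nM (2 entries), two entries that lie far apart.

Compound 3 `COc1cccc(/C=C2\NC(=O)NC2=O)n1` follows from compound 2 by a single structural change: methoxy in place of thiophen-2-yl on an aromatic carbon. Methoxy takes the place of thiophen-2-yl on an aromatic carbon, next to the ring nitrogen, and the rest of the structure stays the same. Within the data shown here, no measured pair of compounds shows what such an exchange does in this assay, so any expectation here is tentative. A moderate move towards a lower number is expected, though a result within the usual scatter would not be surprising. The range is kept wide since compound 1 alone spans 10600000 nM; 94000 nM (2 entries). The expected change is a 2.6-fold lower number from compound 2 to compound 3 (0.41 log units; beyond the scatter). For compound 3 the estimated value is 12000000 nM, with an expected range from 500000 nM to 60000000 nM.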

Compound 3, half-maximal inhibitory concentration: 16700000 nM
Estimate against measurement, compound 3: 1.4-fold (0.14 log units) below; the range from low to high includes it.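

In this assay, going by these compounds alone, the exchange gives the first step that can be read in one place: a 1.8-fold lower number from compound 2 to compound 3 (0.27 log units; within the scatter). Within the data shown here, on this aromatic carbon next to the ring nitrogen, then, thiophen-2-yl with its 5 heavy atoms and one five-membered aromatic ring gives way to methoxy with 2 heavy atoms and no ring, and the read-out does not move beyond the scatter, which the earlier compounds could not show. The step is also small beside the spread that a single compound can show across its own entries: the several entries of compound 1 in this assay, 10600000 nM; 94000 nM (2 entries)

On these data alone, what an amine, a carboxylic acid or a longer chain such as ethoxy on this same carbon would give in this assay remains open, so it cannot yet be said whether the read-out responds to this position at all. Compound 1 differs from compound 2 and compound 3 in more than one place, so it cannot be linked to them by a step, and nothing shown here tells what the ring nitrogen or the placement of the substituent contributes.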